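This account rests on a few compounds, and the source may have more. Where it says the series, first, only, none or still open, it means among the compounds named here.

Measured so far in an ADME assay on 184B5 cells (Homo sapiens) for cytotoxicity, read by MTT assay, with a stated time of 72 h; a lower number here means a stronger inhibitor of growth, a higher number a weaker inhibitor of growth:

- compound 1, `CCCCC[Se]c1nc(NCc2ccc(SC)cc2)c2ccccc2n1`: compound 1 gives > 100000 nM
- compound 2, `CSc1ccc(CNc2nc([SeH])nc3ccccc23)cc1`: compound 2 gives 86300 nM
- compound 3, `Nc1nc([SeH])nc2ncccc12`: compound 3 gives 31100 nM

The value of compound 1 is a limit of this assay, not a number; this is the limit of > 100000 nM in this assay, at which 1 of the 3 values shown sits. Compound 3 has the lowest of the two numbers, with compound 2 nearest at a wider spread than repeat measurements give. The difference between the core of compound 3 and the core of compound 2 is not broken down here.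

The step from compound 2 to compound 1 is pentyl in place of hydrogen on a selenium, and it gives an at least 1.1-fold higher number from compound 2 to compound 1 (0.06 log units; that floor lies within the scatter), a floor set only by the limit of compound 1.

Compound 4, `CCCCC[Se]c1nc(N)c2cccnc2n1`, is not yet measured. It differs from compound 3 by pentyl in place of hydrogen on a selenium, the same change as from compound 2 to compound 1, at a place described in the same words. On the measured pair this change did not lower the number, so a higher number than compound 3 is expected for compound 4, of about a 1.9-fold higher number from compound 3 to compound 4 (0.29 log units; within the scatter). Compound 4 is estimated at 60000 nM, within 25000 nM to 150000 nM.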

Compound 4, concentration for total growth inhibition: 40200 nM
Compound 4: the middle estimate sits 1.5-fold (0.17 log units) above what was measured, and the stated range covers the measured number.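

In this assay, pentyl in place of hydrogen on a selenium gives a 1.3-fold higher number from compound 3 to compound 4 (0.11 log units; within the scatter), so on the core of compound 3 the change has no effect that can be told from the scatter. On the other core, compound 1 gives > 100000 nM, which is a limit of the assay and not a number. Neither core shows the change lowering the number, but this does not show that a step of the same size carries from one core to the other: the same change on two cores in this assay, an at least 1.1-fold higher number (0.06 log units; that floor lies within the scatter) from compound 2 to compound 1 and a 1.3-fold higher number (0.11 log units; within the scatter) from compound 3 to compound 4; the limit leaves it open whether they differ

Still open, as far as these compounds go, is whether a shorter chain such as methyl, or a longer chain than pentyl, on the selenium would give a step beyond the scatter on either core. Also open, from the compounds shown here alone, is what a pentyl chain ending in an amine or a carboxylic acid would do in this assay.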